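Compound 2 to compound 3: an aryl swap on the shared core

The source may report more compounds than this note shows. Statements on the series, on what has been measured and on what is new or still open speak of the compounds shown alone.

For the measured compounds named here, in a functional assay on HepG2 cells (Homo sapiens) for antiproliferative activity, read by MTT assay, with a stated time of 48 h (a lower number here means a stronger inhibitor, a higher number a weaker inhibitor), compound 1 `CC(=O)N1N=C(c2ccc3ccccc3c2)OC1c1cccc(Br)c1` gives 1.68 ug/mL and compound 2 `CC(=O)N1N=C(c2ccc3ccccc3c2)OC1c1ccncc1` gives 2.17 ug/mL so compound 2 stands within the scatter of the only other measured value. Compound 3 `CC(=O)N1N=C(c2ccc3ccccc3c2)OC1c1ccc(C)cc1` carries 4-methylphenyl in place of pyridin-4-yl on a saturated ring carbon. Going by the values given here, the only measured step at that carbon is a 1.3-fold higher number from compound 1 to compound 2 (0.11 log units; within the scatter) and it is small, so no change beyond the scatter is expected in this assay for this swap. The estimated step is a 1.1-fold lower number from compound 2 to compound 3 (0.04 log units; within the scatter) and its direction is uncertain. Compound 3 is expected at 2 ug/mL with an estimated range of 0.9 ug/mL to 4.5 ug/mL in this read-out.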

Compound 3, half-maximal inhibitory concentration: 2.26 ug/mL
Compound 3: middle estimate off by 1.1-fold (0.05 log units), on the low side, within the range that was stated.
By their numbers in this assay, from the lowest: compounds 1, 2 and 3 (each within the scatter of the next).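

In this assay, 4-methylphenyl in place of pyridin-4-yl gives a 1.0-fold higher number from compound 2 to compound 3 (0.02 log units; within the scatter), and 4-methylphenyl in place of 3-bromophenyl gives a 1.3-fold higher number from compound 1 to compound 3 (0.13 log units; within the scatter). The saturated ring carbon now carries three different aryl groups, and exchanging the ring nitrogen and hydrogen-bond acceptor of pyridin-4-yl for an all-carbon ring with a methyl group produces no step beyond the scatter. No supporting data bear on this result.

Still open, from the compounds shown here alone, is whether an amine or a carboxylic acid on the aryl ring, or a longer chain in place of that ring, would move the number beyond the scatter.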